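The source may report more compounds than this note shows. Statements on the series, on what has been measured and on what is new or still open speak of the compounds shown alone.

Measured so far in a functional assay on the whole organism with Mus musculus as the target, in the rotarod test; on this read-out lower numbers stand for an effect already at smaller amounts and higher numbers for an effect only at larger amounts of compound:

- compound 1, `CC(=O)NCC(=O)Nc1ccc(Cl)cc1C(=O)c1ccccc1`: > 100 mg/kg
- compound 2, `NCC(=O)NCC(=O)Nc1ccc([N+](=O)[O-])cc1C(=O)c1ccccc1Cl`: 63.9 mg/kg
- compound 3, `CC(=O)NCC(=O)N(C)c1ccc(Cl)cc1C(=O)c1ccccc1Cl`: 58 mg/kg

Compound 1's entry > 100 mg/kg is a limit of this assay, not a number; the line the limit of > 100 mg/kg in this assay, at which 1 of the 3 values shown sits, records it as such. Among the numbers proper, compound 3 gives 58 mg/kg and compound 2 gives 63.9 mg/kg, and the two lie within the usual scatter of one another, so no order between them can be read from this assay. Going by the values given here, nothing in the set connects these compounds by a single change, so no measured step is available.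

Compound 4, `CN(C(=O)CNC(=O)CN)c1ccc(Cl)cc1C(=O)c1ccccc1Cl`, is the next compound to be measured. It differs from compound 3 in one place: amino in place of hydrogen on a saturated chain carbon bound to a carbonyl carbon. Compound 2 already carries an amino group on a saturated chain carbon bound to a carbonyl carbon and gives 63.9 mg/kg, a number close to that of compound 3, which gives no sign that such a group moves the read-out far. The step from compound 3 to compound 4 is therefore expected to stay within the scatter, a 1.0-fold higher number from compound 3 to compound 4 (0.01 log units; within the scatter). For compound 4 the expected value in this assay is 60 mg/kg, with a range from 25 mg/kg to 150 mg/kg.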

Compound 4, dose for half-maximal effect: 27.7 mg/kg
Estimate against measurement, compound 4: 2.2-fold (0.34 log units) above; the measured number falls inside the stated range.
By their numbers in this assay, from the lowest: compound 4; then compounds 3 and 2 (each within the scatter of the next). At a limit, above all of these: compound 1.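

In this assay, amino in place of hydrogen on a saturated chain carbon bound to a carbonyl carbon comes with a 2.1-fold lower number from compound 3 to compound 4 (0.32 log units; beyond the scatter), a modest step but the first in the series that isolates a single change. Compound 2 also carries this amino group, but it differs from compound 3 in more than one place, so its value could not show what the group contributes; this pair shows that the read-out responds to a change at this place on the chain, moving towards an effect at smaller amounts of compound. No measurement shown here bears on why the number moves.

Still open, on these data alone, is whether a hydroxyl group, a dimethylamino group or a longer aminoalkyl chain at this place would give a number like that of compound 4, or whether the step is specific to the primary amine. Also open, as far as these compounds go, is whether the same change gives a step of similar size on a core carrying a nitro group in place of the chlorine, or without the methyl group on the amide nitrogen.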